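A few compounds are considered here, and "the series" means these few. Any claim that something is new, unique, unknown or untested is made for them only; others in the source may bear on it.

Of the compounds shown here, two have so far been measured in a functional assay on RPMI-8226 cells (Homo sapiens) for cytotoxicity, read by sulforhodamine B assay, with a stated time of 48 h, tested at 10 uM; on this read-out lower numbers stand for a stronger effect and higher numbers for a weaker effect at the one concentration tested. Compound 1 `COc1ccc(-c2cc(/C=C/C(=O)c3ccc(N)cc3)[nH]n2)cc1` gives -35%, while compound 2 `COc1cc(-c2cc(/C=C/C(=O)c3ccc(Cl)c(Cl)c3)[nH]n2)cc(OC)c1OC` gives -7%, the higher of the two numbers and so the weaker effect, with a gap to compound 1 that lies beyond the usual scatter. Compound 3 `COc1cc(-c2cc(/C=C/C(=O)c3ccc(F)c(F)c3)[nH]n2)cc(OC)c1OC` is not yet measured; it differs from compound 2 by 3,4-difluorophenyl in place of 3,4-dichlorophenyl on a carbonyl carbon. No measured step of this kind exists among these compounds, so the move from compound 2 to compound 3 is expected to stay within the scatter, or at most to lean slightly towards a weaker effect. Compound 3 is therefore estimated at -2% in this assay, with a range from -25% to 20%. This expectation amounts to a step of a number 5 percentage points higher from compound 2 to compound 3 (within the scatter).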

Compound 3, a percentage reported as activity, at one concentration (the size of the read-out at that concentration, not a potency): -21%
For compound 3 the middle estimate is 19 percentage points above the measured one, within the range that was stated.
By their numbers in this assay, from the lowest: compound 1; then compound 3; then compound 2.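

In this assay, 3,4-difluorophenyl in place of 3,4-dichlorophenyl on a carbonyl carbon gives a number 14 percentage points lower from compound 2 to compound 3 (beyond the scatter). This first single-place comparison shows that the read-out responds to which halogen pair this ring carries, although both groups have the same count of heavy atoms, with the stronger effect lying with the 3,4-difluorophenyl. Nothing measured here accounts for the step. Where a 3,4-dibromophenyl or an unsubstituted phenyl would fall at this place remains open, as does whether the same step would hold on the core of compound 1.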